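The compounds below may be only part of what the source reports. "The series", "measured", "known", "first", "only" and "open" are said of these compounds alone.

Compound 3 `O=[N+]([O-])c1ccc(-c2nc(CO[C@@H]3O[C@H](CSc4ncn[nH]4)[C@H]4OC5(CCCC5)O[C@@H]34)no2)cc1` gives the lowest number among the three compounds measured in a functional assay on A549 cells (Homo sapiens) for antiproliferative activity, read by sulforhodamine B assay, with a stated time of 48 h (a higher number here means a weaker inhibitor of growth, a lower number a stronger inhibitor of growth), with 10000 nM. Its nearest neighbour is compound 1 `Nc1nnc(SC[C@H]2O[C@@H](OCc3noc(-c4ccc(Cl)cc4)n3)[C@@H]3OC4(CCCC4)O[C@@H]32)s1`, which in this assay gives 15000 nM, a gap within the scatter. Compound 2 `COc1cc(-c2nc(CO[C@@H]3O[C@H](CSc4ncn[nH]4)[C@H]4OC5(CCCC5)O[C@@H]34)no2)cc(OC)c1OC` gives 28000 nM, and the step of a 2.8-fold lower number from compound 2 to compound 3 (0.45 log units; beyond the scatter) is modest but beyond the scatter. Compound 4 `Clc1ccc(-c2nc(CO[C@@H]3O[C@H](CSc4ncn[nH]4)[C@H]4OC5(CCCC5)O[C@@H]34)no2)cc1` differs from compound 3 by chloro in place of nitro on an aromatic carbon. Among the compounds with values here, no measured step turns on chloro against nitro; the only step at this position, from compound 2 to compound 3, concerns a different exchange, and compound 1, which carries the same chlorophenyl group on a different core, gives a number within the scatter of compound 3. Compound 4 is therefore expected to show a 1.3-fold higher number from compound 3 to compound 4 (0.11 log units; within the scatter), with an estimate of 13000 nM in the range 5000 nM to 35000 nM.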

Compound 4, concentration for 50% growth inhibition: 13000 nM
For compound 4 middle estimate and measured number coincide at the digits printed, within the range that was stated.
By their numbers in this assay, from the lowest: compounds 3, 4, 1 and 2 (each within the scatter of the next, the first and the last beyond it).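

In this assay, chloro in place of nitro gives a 1.3-fold higher number from compound 3 to compound 4 (0.11 log units; within the scatter) and so leaves the two groups indistinguishable at this place, while a 2.2-fold lower number from compound 2 to compound 4 (0.33 log units; beyond the scatter) shows that 4-chlorophenyl, like 4-nitrophenyl, stands apart from 3,4,5-trimethoxyphenyl. With 4-chlorophenyl held constant, the exchange on the sulfur gives a 1.2-fold lower number from compound 1 to compound 4 (0.06 log units; within the scatter) and separates neither group from the other. No evidence is available to explain these results. The compounds shown leave open whether an amine or a carboxylic acid at this place would shift the number. They also leave open how a methoxy group alone would compare.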